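Toxicity on MT4 cells: from ketone to anilide

The source may report more compounds than this note shows. Statements on the series, on what has been measured and on what is new or still open speak of the compounds shown alone.

Compound 1 `O=C(CSc1nncnc1-c1ccccc1Cl)c1ccc(Cl)c(Cl)c1` and compound 2 `O=C(CSc1nncnc1-c1cccc2ccccc12)Nc1ccccc1` share a core and were both tested in an ADME assay on MT4 cells (Homo sapiens) for cytotoxicity, read by MTT assay; on this read-out higher numbers stand for lower toxicity in this test and lower numbers for higher toxicity in this test. Compound 1 gives 33000 nM, the lowest of the two numbers, and compound 2 gives 154000 nM. Compound 3 `O=C(CSc1nncnc1-c1ccccc1Cl)Nc1ccccc1Cl` is not yet measured. It differs from compound 1 by (2-chlorophenyl)amino in place of 3,4-dichlorophenyl on a carbonyl carbon. Compound 2, which also carries an amino group on the carbonyl carbon, shows the higher number, so a rise beyond the scatter is expected, though of uncertain size; the expected step is a 2.4-fold higher number from compound 1 to compound 3 (0.38 log units; beyond the scatter). For compound 3 the estimate is 80000 nM, within 30000 nM to 220000 nM.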

Compound 3, half-maximal cytotoxic concentration: 90000 nM
Compound 3: the middle estimate sits 1.1-fold (0.05 log units) below what was measured, and the stated range covers the measured number.
By their numbers in this assay, from the lowest: compound 1; then compounds 3 and 2 (each within the scatter of the next).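

In this assay, putting (2-chlorophenyl)amino in place of 3,4-dichlorophenyl on a carbonyl carbon gives a 2.7-fold higher number from compound 1 to compound 3 (0.44 log units; beyond the scatter) with the rest of the molecule unchanged. Within the data shown here, this is the first pair that isolates this position, so the rise in the number can now be tied to this one change. Nothing measured here explains the rise.

The swap adds an amino nitrogen and also changes the chlorine pattern, and these two changes cannot be told apart. Going by these compounds, how an unsubstituted anilino group, a simple alkyl amine or a carboxylic acid would behave at this carbon remains open.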